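The source may report more compounds than this note shows. Statements on the series, on what has been measured and on what is new or still open speak of the compounds shown alone.

In a functional assay on A549 cells (Homo sapiens) for antiproliferative activity, with a stated time of 72 h (on this read-out higher numbers stand for weaker inhibition and lower numbers for stronger inhibition), compound 1 (`CC(=O)Oc1ccc(/C=C/c2nc3ccccc3c(=O)[nH]2)c(OC(C)=O)c1`) gives > 25000 nM as a limit of the assay and not a number. Compound 2 (`COc1ccccc1/C=C/c1nc(Nc2ccccc2Cl)c2ccccc2n1`) gives > 25000 nM as a limit too, so it stands where the limit of > 25000 nM in this assay, at which 2 of the 2 values shown sit, shows, with no exact number to start from. Compound 3 (`COc1ccccc1/C=C/c1nc(Nc2cccc(O)c2)c2ccccc2n1`) has 3-hydroxyphenyl in place of 2-chlorophenyl on a nitrogen on an aromatic ring. Among the measured compounds shown here, no measured step guides this change, so a modest move towards stronger inhibition is expected, with an estimated step of an at least 2.5-fold lower number from compound 2 to compound 3 (0.39 log units; beyond the scatter) as the group changes. The expected value for compound 3 is 10000 nM within an estimated range of 2000 nM to 40000 nM on this read-out.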

Compound 3, half-maximal inhibitory concentration: 16600 nM
Compound 3: middle estimate off by 1.7-fold (0.22 log units), on the low side; the range from low to high includes it.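

Placing 3-hydroxyphenyl instead of 2-chlorophenyl on this nitrogen gives the first exact number in this assay, so the group at this position can bring a compound off the limit. The size of the change stays uncertain, and the step can only be read as an at least 1.5-fold lower number from compound 2 to compound 3 (0.17 log units; that floor lies within the scatter). Only compound 3 has an exact value so far: the limit of > 25000 nM in this assay, at which 2 of the 3 values shown sit.

From the compounds shown here alone, it remains open whether the change comes from losing the chlorine or from gaining the hydroxyl group. Also open, going by these compounds, is how an amine or a carboxylic acid on that phenyl ring would compare with 3-hydroxyphenyl.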